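The compounds below may be only part of what the source reports. "The series", "measured", "known", "first", "only" and "open" are said of these compounds alone.

Measured compounds:
compound 1, `Nc1nc(Cl)c2ncn(Cc3ccccc3CCl)c2n1` — 26300 nM
compound 2, `ClCc1cccc(Cn2cnc3nc(Cl)nc(Cl)c32)c1` — 2450 nM

In a functional assay on SK-MEL-5 cells (Homo sapiens) for cytotoxicity, read by sulforhodamine B assay, with a stated time of 48 h (a higher number here means a weaker inhibitor of growth, a lower number a stronger inhibitor of growth), compound 1 gives 26300 nM, the higher of the two numbers recorded so far. Compound 2 gives 2450 nM in this assay, a lower number that lies beyond the usual scatter; compound 2 differs from compound 1 in more than one place, so its value says nothing direct about any single change.

Compound 3, `ClCc1ccccc1Cn1cnc2c(Cl)ncnc21`, has not yet been measured in this assay. It is derived from compound 1 by one change: hydrogen in place of amino on an aromatic carbon. Going by the values given here, no measured pair shows the effect of this change on its own, so the step can only be guessed. The amino group that leaves carries a hydrogen-bond donor and acceptor; with nothing in the series to anchor the direction, the expected step of a 1.9-fold lower number from compound 1 to compound 3 (0.27 log units; within the scatter) is small, a modest move toward a lower number at most, and may fall within the scatter. Compound 3 is therefore estimated at 14000 nM in this assay, with a likely range from 4000 nM to 45000 nM.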

Compound 3, concentration for total growth inhibition: 2880 nM
Compound 3: the middle estimate sits 4.9-fold (0.69 log units) above what was measured; the whole stated range lies above it.
By their numbers in this assay, from the lowest: compounds 2 and 3 (each within the scatter of the next); then compound 1.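

In this assay, going by these compounds alone, hydrogen in place of amino on the aromatic carbon between two ring nitrogen atoms gives a 9.1-fold lower number from compound 1 to compound 3 (0.96 log units; beyond the scatter), the first single-change step. Within this pair, with the rest of the structure unchanged, the amino group accompanies the weaker growth inhibition, showing that this position can shift the read-out beyond the scatter. No supporting measurement accounts for the direction or size of this step.

This single pair cannot show whether the step carries over to other substitution patterns on the shared core. It also leaves open where a methyl, methoxy or dimethylamino group on this same carbon would fall relative to hydrogen and amino.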